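Sulfonyl substituent change in the alkyne thiazole series

The source may hold more compounds than are shown below. What is called first, only, known or untested is meant among the compounds shown, and "the series" means these compounds.

Three compounds have numbers in an assay on HEK293 cells for negative allosteric modulation of metabotropic glutamate receptor 5 (Homo sapiens), read by FLIPR, with a stated time of 1 h; a higher number here means a weaker inhibitor, a lower number a stronger inhibitor. Compound 1 `O=C(C1CCC1)N1CCc2nc(C#Cc3ccccc3)sc2C1` gives 370 nM. Compound 2 `CC(C)S(=O)(=O)N1Cc2nc(C#Cc3ccccc3)sc2C1` gives 140 nM and stands second highest of the three, with compound 1 nearest and compound 3 furthest. Compound 3 `O=S(=O)(C1CC1)N1CCc2nc(C#Cc3ccccc3)sc2C1` gives 34 nM. Within the data shown here, the one single-place step, an 11-fold lower number from compound 1 to compound 3 (1.04 log units; beyond the scatter), is large, but it alters the group on the ring amine nitrogen, not the group on the sulfonyl sulfur. Among the measured compounds shown here, compound 2 and compound 3 differ in more than one place, so their two values show only that the smaller number belongs to compound 3.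

Compound 4 `O=S(=O)(N1CCCCC1)N1Cc2nc(C#Cc3ccccc3)sc2C1` differs from compound 2 by piperidin-1-yl in place of isopropyl on a sulfonyl sulfur. For the measured compounds named here, no measured step changes the group on the sulfonyl sulfur, so nothing here sets the size or direction of this change. Compound 4 is therefore expected to stay close to compound 2, with the step of a 1.4-fold higher number from compound 2 to compound 4 (0.15 log units; within the scatter) expected to fall within the scatter. The estimate for compound 4 in this assay is 200 nM, with a range from 60 nM to 700 nM.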

Compound 4, half-maximal inhibitory concentration: > 10000 nM
Compound 4: a limit, no number; the forecaster's own chance of this, stated with the estimate: 5%; middle value at least 50-fold (1.69 log units) from the limit.
By their numbers in this assay, from the lowest: compound 3; then compound 2; then compound 1. At a limit, above all of these: compound 4.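

Notes on the sulfonyl sulfur: this is the first single-place change read at this position, and the position is not indifferent to the group it carries. In this assay, piperidin-1-yl in place of isopropyl gives an at least 71-fold higher number from compound 2 to compound 4 (1.85 log units; beyond the scatter), a large step in the direction of weaker inhibition. The value for compound 4 is a limit of the assay and not a number: the limit of > 10000 nM in this assay, at which 1 of the 4 values shown sits.

The compounds shown leave open whether this step goes with the six-membered non-aromatic ring, its nitrogen or the rise from 3 to 6 heavy atoms in the group. They also leave open how a cyclohexyl group or a dimethylamino group on the same sulfonyl sulfur would read in this assay, and so where along such groups the loss sets in.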